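This account rests on a few compounds, and the source may have more. Where it says the series, first, only, none or still open, it means among the compounds named here.

Working notes on the series

The shared core is seen in compound 1 `NC(=O)c1cc(-c2ccc(NS(=O)(=O)c3cccc(Cl)c3Cl)cc2)nc2[nH]ncc12`, whose amide carries only hydrogen. In an assay for inhibition of serine/threonine-protein kinase Sgk1 (Homo sapiens), with stated times of 30 min and 60 min, in the presence of a further agent that is not named here (on this read-out higher numbers stand for weaker inhibition and lower numbers for stronger inhibition), compound 1 gives 1 nM. Compound 2 `CCNC(=O)c1cc(-c2ccc(NS(=O)(=O)c3cccc(Cl)c3Cl)cc2)nc2[nH]ncc12` puts an ethyl on the amide nitrogen and in this assay gives 6 nM, the change being a 6.0-fold higher number from compound 1 to compound 2 (0.78 log units; beyond the scatter). Compound 3 `NCCNC(=O)c1cc(-c2ccc(NS(=O)(=O)c3cccc(Cl)c3Cl)cc2)nc2[nH]ncc12` carries a 2-aminoethyl on that nitrogen. In this assay compound 3 reaches only the limit < 1 nM, so no number is read for it. From the hydrogen of compound 1 the step reads a number no higher from compound 1 to compound 3 (the limit leaves the size open), and from the ethyl of compound 2 it reads an at least 6.0-fold lower number from compound 2 to compound 3 (0.77 log units; beyond the scatter). Compound 3 therefore stands at the floor of the reported numbers, and the limit of < 1 nM in this assay, at which 1 of the 3 values shown sits, leaves its true size open.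

Compound 4 `CN1CCC(CNC(=O)c2cc(-c3ccc(NS(=O)(=O)c4cccc(Cl)c4Cl)cc3)nc3[nH]ncc23)C1` alters the chain: 1-methylpyrrolidin-3-yl in place of aminomethyl on a saturated chain carbon bound to an amide-type nitrogen. The hydrogen-bond donor of the chain leaves while a larger ring-bound nitrogen acceptor enters. The step from compound 2 to compound 3 shows what the amino gained, and the step from compound 1 to compound 2 shows what added alkyl cost; both were modest. A modest move toward weaker inhibition is expected, the step of an at least 3.0-fold higher number from compound 3 to compound 4 (0.47 log units; beyond the scatter) being an estimate. Compound 4 is thus expected near 3 nM, between 0.7 nM and 15 nM.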

Compound 4, half-maximal inhibitory concentration: 14 nM
Estimate against measurement, compound 4: 4.7-fold (0.67 log units) below; low and high end bracket the measured number.
By their numbers in this assay, from the lowest: compound 1; then compound 2; then compound 4.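

Against the ethyl of the earlier series, the (1-methylpyrrolidin-3-yl)methyl group on the amide nitrogen is only a modest step in this assay, with a 2.3-fold higher number from compound 2 to compound 4 (0.37 log units; beyond the scatter), so this position still gives a low number with a ring-bearing group on the chain. Against the amide that carries only hydrogen the same group is a large step, with a 14-fold higher number from compound 1 to compound 4 (1.15 log units; beyond the scatter), which extends the cost of substitution on this nitrogen beyond what the ethyl showed. Against the 2-aminoethyl chain the change is also large, with an at least 14-fold higher number from compound 3 to compound 4 (1.14 log units; beyond the scatter), and this step is open in size, its lower end being a limit and not a number: the limit of < 1 nM in this assay, at which 1 of the 4 values shown sits.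

The change from aminomethyl to 1-methylpyrrolidin-3-yl swaps the terminal amine, adds a ring and enlarges the group all at once, and the compounds shown do not separate these contributions. A dimethylamino group at the end of the ethyl chain, or a pyrrolidin-3-yl without the methyl, would each change only one of them.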